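Swapping the thiophene on a hydrazone-type core

This account rests on a few compounds, and the source may have more. Where it says the series, first, only, none or still open, it means among the compounds named here.

Compound 1 `Cc1csc(C(=O)/C=C/c2ccc(N3CCCCC3)cc2)c1` is an open-chain relative; in an ADME assay on PBMC cells (Homo sapiens) for cytotoxicity, with a stated time of 5 days (a lower number here means a stronger inhibitor, a higher number a weaker inhibitor), compound 1 gives 68800 nM. Compound 2 `c1cc(C2=NNC(c3ccc(N4CCCCC4)cc3)C2)cs1` shares the piperidinyl-phenyl end but closes the linker into a five-membered ring with two nitrogens. For compound 2 this assay reports only a limit, > 100000 nM, not a number. This is the limit of > 100000 nM in this assay, at which 1 of the 2 values shown sits. Compound 3 `Cc1ccc(C2=NNC(c3ccc(N4CCCCC4)cc3)C2)s1` differs from compound 2 in one place: 5-methylthiophen-2-yl in place of thiophen-3-yl on a carbon with a double bond to nitrogen. Going by the values given here, no measured pair shows what such a swap does here, and compound 2 itself sits at the limit, so no step beyond the scatter is expected; the step is estimated as a step that the limit leaves unreadable from compound 2 to compound 3. Compound 3 is expected to land at about 130000 nM, within a range from 50000 nM to 350000 nM, most likely again reported only as a limit.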

Compound 3, half-maximal inhibitory concentration: 86400 nM
For compound 3 the middle estimate is 1.5-fold (0.18 log units) above the measured one, and the stated range covers the measured number.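

For compound 2, > 100000 nM is a limit of the assay and not a number. Compound 3, with 5-methylthiophen-2-yl in place of thiophen-3-yl on a carbon with a double bond to nitrogen, gives a real number in this assay, and the swap brings an at least 1.1-fold lower number from compound 2 to compound 3 (0.06 log units; that floor lies within the scatter). That floor is all that can be read, and the full size of the step stays unknown because one end of it is not a number: the limit of > 100000 nM in this assay, at which 1 of the 3 values shown sits.

The swap changes two things at once, adding the methyl group and moving the point of attachment on the thiophene, and the compounds shown do not separate the two. They also leave open how a plain phenyl ring, or a thiophene carrying a carboxylic acid or an amine, would read at this place.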